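Aryl swap on the amide nitrogen: compound 2 to compound 3

The source may hold more compounds than are shown below. What is called first, only, known or untested is meant among the compounds shown, and "the series" means these compounds.

Of the compounds shown here, two have numbers so far. Compound 1 `COc1ccc(CCC(=O)N(c2nccc3ccccc23)[C@@H]2CCCNC2)cc1` gives 1 in a physicochemical assay for lipophilicity, using the shake flask method; on this read-out lower numbers stand for lower lipophilicity and higher numbers for higher lipophilicity. Compound 2 `O=C(N1CCC(c2ccccc2)CC1)N(c1nccc2ccccc12)[C@@H]1CCCNC1` gives 1.4 in this assay, the higher of the two numbers; compound 1 sits lower by a gap that is beyond the usual scatter. Among the measured compounds shown here, the two compounds differ in more than one place, so no single step connects them, and the pair only shows that the series so far spans a modest window of the read-out.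

Compound 3 `Cc1nccnc1N(C(=O)N1CCC(c2ccccc2)CC1)[C@@H]1CCCNC1` has not been measured. It differs from compound 2 in one place: 3-methylpyrazin-2-yl in place of isoquinolin-1-yl on an amide-type nitrogen. For the measured compounds named here, no measured pair carries this change, so the expectation rests on the change alone and on the position of compound 2. In this assay the change is expected to give a downward step beyond the scatter, estimated at a number 1.00 log units lower from compound 2 to compound 3 (beyond the scatter). Compound 3 is therefore estimated at 0.4, with a range from -0.3 to 1, pending the measurement.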

Compound 3, distribution coefficient: 0.3
Beside the measured number, compound 3's estimate is 0.10 log units above it, within the range that was stated.
By their numbers in this assay, from the lowest: compound 3; then compound 1; then compound 2.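

In this assay, among the compounds shown here, the amide-type nitrogen proves to be a position where a single change moves the read-out: 3-methylpyrazin-2-yl in place of isoquinolin-1-yl gives a number 1.10 log units lower from compound 2 to compound 3 (beyond the scatter) with the rest of the molecule held constant, the first single-place step and one that the earlier pair, differing in more than one place, could not provide. The change alters several counted features at once, going from 10 heavy atoms to 7, from two aromatic rings to one, and from 1 hydrogen-bond acceptor to 2, and this single step cannot separate their contributions. No supporting measurement bears on the origin of the step.

The compounds shown leave open whether the step follows the loss of the second ring, the added ring nitrogen or the methyl group, a question that a pyrazin-2-yl group without the methyl or a pyridin-2-yl group at the same nitrogen would address. Also open, from the compounds shown here alone, is whether the same change gives a step of similar size on compound 1, with its different acyl group.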